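Pyrrolidin-1-yl to diethylamino on the amide side chain

The source may report more compounds than this note shows. Statements on the series, on what has been measured and on what is new or still open speak of the compounds shown alone.

Measured in a functional assay on A549 cells (Homo sapiens) for inhibition; a lower number here means a stronger inhibitor, a higher number a weaker inhibitor:
compound 1 `CCN(CC)CCNC(=O)CC(CC(=O)NC1Cc2ccccc2C1)c1ccc(Cl)cc1` gives 48600 nM as a number
compound 2 `O=C(CC(CC(=O)NC1Cc2ccccc2C1)c1ccccc1)NCCN1CCCCC1` gives > 100000 nM as a limit
compound 3 `O=C(CC(CC(=O)NC1Cc2ccccc2C1)c1ccccc1)NCCN1CCCC1` gives > 100000 nM as a limit

Compound 3 has no number to step from, since it stands at the limit of > 100000 nM in this assay, at which 2 of the 3 values shown sit, in this series. The next structure is compound 4 `CCN(CC)CCNC(=O)CC(CC(=O)NC1Cc2ccccc2C1)c1ccccc1`, with diethylamino in place of pyrrolidin-1-yl on a saturated chain carbon, two bonds along the chain from an amide-type nitrogen.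

Going by the values given here, the one measured step at this place, a step that the two limits leave unreadable from compound 2 to compound 3, offers no size to carry over. The nearest guide is compound 1, which also carries 2-(diethylamino)ethyl and gives 48600 nM as a number in this assay, though it differs from compound 4 elsewhere as well. On that single comparison, a modest move towards stronger inhibition is expected, and a further reading at the limit remains quite likely. The expected step is an at least 1.1-fold lower number from compound 3 to compound 4 (0.07 log units; that floor lies within the scatter), and its size is uncertain given the limit it starts from. For compound 4 the estimate is 85000 nM, with an expected range of 35000 nM to 200000 nM in the same read-out.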

Compound 4, half-maximal inhibitory concentration: 82400 nM
The estimate for compound 4 lay 1.0-fold (0.01 log units) above the measured number; low and high end bracket the measured number.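

With diethylamino in place of the ring amines on the side chain, this assay yields a number for a compound carrying hydrogen instead of chloro on the aromatic carbon, and the change reads as an at least 1.2-fold lower number from compound 3 to compound 4 (0.08 log units; that floor lies within the scatter) and as an at least 1.2-fold lower number from compound 2 to compound 4 (0.08 log units; that floor lies within the scatter). Both figures are floors, not measured sizes, and neither floor clears the scatter, so a real gain from diethylamino is possible but not established, because compound 2 and compound 3 each stand at an assay limit: the limit of > 100000 nM in this assay, at which 2 of the 4 values shown sit. Hydrogen in place of chloro gives a 1.7-fold higher number from compound 1 to compound 4 (0.23 log units; within the scatter), so the chloro group, which looked as if it might account for the number seen for compound 1, is not shown to matter in this assay.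

On these data alone, the step from piperidin-1-yl to pyrrolidin-1-yl cannot be read, so the two ring amines cannot be ranked against each other, and whether chloro on the aromatic carbon would lift either of them to a number remains open. Also open, as far as these compounds go, is how dimethylamino or morpholin-4-yl in place of diethylamino, or 3-(diethylamino)propyl in place of 2-(diethylamino)ethyl, would read.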